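From compound 3 to compound 4

The compounds below may be only part of what the source reports. "The series", "measured", "known", "first", "only" and "open" are said of these compounds alone.

In an ADME assay on the whole organism for pharmacokinetics, with Rattus norvegicus as the target (on this read-out lower numbers stand for a shorter-lived compound and higher numbers for a longer-lived compound), compound 1 (`CCCS(=O)(=O)c1cc(C)cc(C)c1NC(=O)c1sccc1S(=O)(=O)Nc1onc(C)c1Cl`) gives 1.3 h and compound 2 (`Cc1cc(C)c(NC(=O)c2sccc2S(=O)(=O)Nc2onc(C)c2Cl)c(C(=O)c2ccccc2)c1`) gives 3.95 h on the same scale. Compound 3 (`Cc1cc(C)c(NC(=O)c2sccc2S(=O)(=O)Nc2onc(C)c2Cl)c(C(=O)CS(C)(=O)=O)c1`) gives 12.2 h as the highest of the three numbers.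

Compound 4 (`C/C(=N\O)c1cc(C)cc(C)c1NC(=O)c1sccc1S(=O)(=O)Nc1onc(C)c1Cl`) differs from compound 3 by one change: a group of 4 heavy atoms (2 carbon, 1 nitrogen, 1 oxygen; no ring) in place of a group of 7 heavy atoms (3 carbon, 3 oxygen, 1 sulfur; no ring), on an aromatic carbon and the entering group has no common name. The ((methylsulfonyl)methyl)carbonyl group leaves from an aromatic carbon, ortho to a large group.

Among the measured compounds shown here, three measured steps bear on this place, all modest and beyond the scatter: a 3.0-fold higher number from compound 1 to compound 2 (0.48 log units; beyond the scatter) for benzoyl in place of propylsulfonyl, a 9.4-fold higher number from compound 1 to compound 3 (0.97 log units; beyond the scatter) for ((methylsulfonyl)methyl)carbonyl in place of propylsulfonyl, and a 3.1-fold higher number from compound 2 to compound 3 (0.49 log units; beyond the scatter) for (methylsulfonyl)methyl in place of phenyl. For the measured compounds named here, no measured compound carries the entering group. Both other groups measured here give lower numbers than the leaving group, so a modest downward step is expected in this assay and the range stays wide. The expected step is a 2.7-fold lower number from compound 3 to compound 4 (0.43 log units; beyond the scatter) (an estimate, not a measurement). The estimate for compound 4 is 4.5 h (1.5 h to 11 h).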

Compound 4, half-life: 5.2 h
Estimate against measurement, compound 4: 1.2-fold (0.06 log units) below; low and high end bracket the measured number.
By their numbers in this assay, from the lowest: compound 1; then compounds 2 and 4 (each within the scatter of the next); then compound 3.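

In this assay, the group of 4 heavy atoms gives a 2.3-fold lower number from compound 3 to compound 4 (0.37 log units; beyond the scatter), so ((methylsulfonyl)methyl)carbonyl still holds the highest number at this aromatic carbon. The same group gives a 1.3-fold higher number from compound 2 to compound 4 (0.12 log units; within the scatter), which leaves it level with benzoyl despite having no ring, and a 4.0-fold higher number from compound 1 to compound 4 (0.60 log units; beyond the scatter), so all three groups measured in place of propylsulfonyl stand beyond the scatter from compound 1. Heavy-atom count does not order the position: the group of 4 heavy atoms in compound 4 and the group of 8 in compound 2 lie within the scatter of each other, while the group of 6 in compound 1 gives the lowest number.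

Nothing measured here accounts for these differences. As far as these compounds go, whether an amine or a carboxylic acid at this aromatic carbon would reach the number of compound 3, 12.2 h, remains open in this assay.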